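This account rests on a few compounds, and the source may have more. Where it says the series, first, only, none or still open, it means among the compounds named here.

Measured so far:
- compound 1 `CN(C)C(=O)c1cc2cnc(Nc3ccc(NC(=O)C4(C(=O)Nc5cccc(O)c5)CC4)cc3)nc2n1C1CCCC1`: 83.7%
- compound 2 `CN(C)C(=O)c1cc2cnc(Nc3ccc(NC(=O)C4(C(=O)Nc5cccc(C(F)(F)F)c5)CC4)cc3)nc2n1C1CCCC1`: 92.7%
- compound 3 `CN(C)C(=O)c1cc2cnc(Nc3ccc(NC(=O)C4(C(=O)Nc5ccc(C(F)(F)F)cc5)CC4)cc3)nc2n1C1CCCC1`: 94.9%

All three were run in a functional assay on T47D cells (Homo sapiens) for inhibition, read by CCK-8 assay, with a stated time of 72 h, tested at 10 uM; a lower number here means less inhibition of growth, a higher number more inhibition of growth at the concentration tested. Compounds 2 and 3 share atoms and differ only in how the trifluoromethylphenyl is joined (4-(trifluoromethyl)phenyl in place of 3-(trifluoromethyl)phenyl on an amide-type nitrogen); the step of a number 2.2 percentage points higher from compound 2 to compound 3 (within the scatter) is within the scatter, so the two cores read alike here. The hydroxy-for-trifluoromethyl exchange hydroxy in place of trifluoromethyl on an aromatic carbon gives a number 9 percentage points lower from compound 2 to compound 1 (within the scatter). Between compound 1 and compound 3 the step is a number 11.2 percentage points higher from compound 1 to compound 3 (beyond the scatter), the only gap here beyond the scatter; compound 3 stands highest of the three by a margin that is modest against compound 1 and within the scatter against compound 2.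

Compound 4 `CN(C)C(=O)c1cc2cnc(Nc3ccc(NC(=O)C4(C(=O)Nc5ccc(O)cc5)CC4)cc3)nc2n1C1CCCC1` is not yet measured. It follows from compound 3 by hydroxy in place of trifluoromethyl on an aromatic carbon. This is the same kind of change as that from compound 2 to compound 1, but the place differs: there the hydroxy sits meta to a large group, here para to a large group. On the core of compound 3 the expected step is a number 8.9 percentage points lower from compound 3 to compound 4 (within the scatter), set beside the measured exchange because a number 9 percentage points lower from compound 2 to compound 1 (within the scatter) moved the read-out only within the scatter. The estimate for compound 4 in this assay is 86%, expected to fall between 74% and 95%.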

Compound 4, percent growth inhibition at one concentration: 95.8%
Compound 4: the middle estimate sits 9.8 percentage points below what was measured, and the stated range ends below it.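

In this assay, hydroxy in place of trifluoromethyl gives a number 0.9 percentage points higher from compound 3 to compound 4 (within the scatter), and this does not read as a different outcome from the earlier exchange on the other core: the same change on two cores in this assay, a number 9 percentage points lower (within the scatter) from compound 2 to compound 1 and a number 0.9 percentage points higher (within the scatter) from compound 3 to compound 4, 9.9 percentage points apart, within the scatter of two such steps. The exchange therefore has no effect beyond the scatter on either core, but this does not show that it carries over unchanged, as the two steps are too small to separate and the exchange sits at a different place on the ring in each pair. Among the remaining steps, a number 3.1 percentage points higher from compound 2 to compound 4 (within the scatter) separates nothing, while a number 12.1 percentage points higher from compound 1 to compound 4 (beyond the scatter) shows that the 4-hydroxyphenyl and 3-hydroxyphenyl amides do read apart, a result that rests on this one pair.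

Readings at one concentration leave open whether compound 2, compound 3 and compound 4 would differ across a range of concentrations. Also open, going by these compounds, is how an amine or a carboxylic acid would read in place of the hydroxy on the phenyl ring.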